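The compounds below may be only part of what the source reports. "The series", "measured", "known", "first", "only" and "open" are said of these compounds alone.

Measured so far:
- compound 1 `COc1cc(C=C2C(=O)N(c3ccc(Cl)cc3)N(c3ccc(Cl)cc3)C2=O)cc(OC)c1OC`: 10100 nM
- compound 2 `CC(=C1C(=O)N(c2ccc(Cl)cc2)N(c2ccc(Cl)cc2)C1=O)c1ccc(O)cc1`: 55600 nM

In a functional assay on ECa-109 cells (Homo sapiens) for cytotoxicity, read by MTT assay, with a stated time of 72 h (on this read-out higher numbers stand for weaker inhibition and lower numbers for stronger inhibition), compound 1 has the lower of the two numbers, and its gap to compound 2 lies beyond the usual scatter. The next compound, compound 3 `COc1ccc(C=C2C(=O)N(c3ccc(Cl)cc3)N(c3ccc(Cl)cc3)C2=O)cc1OC`, has not yet been measured. It differs from compound 1 by hydrogen in place of methoxy on an aromatic carbon, ortho to a methoxy group (hydrogen in place of methoxy on an aromatic carbon). Within the data shown here, the series offers no measured step between compounds differing in one place, so this expectation is loosely grounded. A small move to a higher number in this assay is expected, possibly none beyond the scatter. The expected step is a 1.5-fold higher number from compound 1 to compound 3 (0.17 log units; within the scatter). For compound 3 the estimated value is 15000 nM, with an expected range of 6000 nM to 40000 nM.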

Compound 3, half-maximal inhibitory concentration: > 128000 nM
Compound 3: a limit, no number (the forecaster's own chance of this, stated with the estimate: 8%); middle value at least 8.5-fold (0.93 log units) from the limit.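

In this assay compound 3 gives > 128000 nM, which is a limit of the assay and not a number. Among these compounds, the first one-place step, hydrogen in place of methoxy on an aromatic carbon ortho to a methoxy group, is large and lies beyond the scatter, with an at least 12-fold higher number from compound 1 to compound 3 (1.10 log units; beyond the scatter), so this position is not indifferent to the change. The step has a lower bound only, and the read-out reaches its end here: the limit of > 128000 nM in this assay, at which 1 of the 3 values shown sits.

The compounds shown compare only hydrogen and methoxy at this position, so it stays open whether an ethoxy group, a fluorine atom or an amine would keep the value of compound 1. From the compounds shown here alone, the actual value of compound 3, and with it the full size of the step, also stays open.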